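Hydrazone in place of hydroxyphenyl imine on the coumarin core

The compounds below may be only part of what the source reports. "The series", "measured", "known", "first", "only" and "open" are said of these compounds alone.

Of the compounds shown here, two have numbers so far. Compound 1 `O=c1cc(/C=N\c2ccccc2O)c2c(OCc3ccccc3)cc(OCc3ccccc3)cc2o1` gives 33100 nM in a functional assay, read by spectrophotometry, with a stated time of 5 min; a higher number here means a weaker inhibitor, a lower number a stronger inhibitor. Compound 2 `O=c1cc(/C=N\Nc2ccc([N+](=O)[O-])cc2[N+](=O)[O-])c2ccc(OCc3ccccc3)cc2o1`, which carries a single benzyloxy group and a dinitrophenylhydrazone, gives 181000 nM in this assay; compound 1 thus stands lowest of the two, with compound 2 a good way above it, beyond the scatter. The two differ in more than one place, so no single step can be read from them.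

Compound 3 `O=c1cc(/C=N\Nc2ccccc2)c2c(OCc3ccccc3)cc(OCc3ccccc3)cc2o1` keeps the core and both benzyloxy groups of compound 1 and alters only the group on the double-bonded nitrogen: anilino in place of 2-hydroxyphenyl on a double-bonded nitrogen. The hydroxyl of compound 1 is gone, and a nitrogen now links the ring to the imine carbon. Among the compounds with values here, no measured pair shows this change on its own. Within the data shown here, the only weaker compound, compound 2, also carries a hydrazone, but with two nitro groups and one benzyloxy group fewer, so it cannot settle the size. A modest rise in the number is expected, within or just beyond the scatter, so that compound 3 is estimated at 55000 nM, with a range from 15000 nM to 200000 nM, a step from compound 1 to compound 3 of a 1.7-fold higher number from compound 1 to compound 3 (0.22 log units; within the scatter).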

Compound 3, half-maximal inhibitory concentration: 303000 nM
Beside the measured number, compound 3's estimate is 5.5-fold (0.74 log units) below it; the whole stated range lies below it.
By their numbers in this assay, from the lowest: compound 1; then compounds 2 and 3 (each within the scatter of the next).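

In this assay, within the data shown here, the exchange of 2-hydroxyphenyl for anilino on a double-bonded nitrogen is the first change that can be read on its own, and it gives a 9.2-fold higher number from compound 1 to compound 3 (0.96 log units; beyond the scatter) with the core and both benzyloxy groups unchanged. This position is therefore sensitive to the exchange, even though the group that leaves and the group that enters have the same counts of heavy atoms, hydrogen-bond donors and hydrogen-bond acceptors, so those counts do not track the step. Nothing at hand accounts for the size of this step.

The exchange removes the hydroxyl and adds a nitrogen link in a single move, so the compounds shown cannot separate the share of each in the step. A 2-hydroxyphenyl hydrazone or a plain phenyl imine on the same core would divide the two parts, while a 2-aminophenyl or 2-carboxyphenyl imine would show whether another group can stand in for the hydroxyl.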